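Swapping a Pyrazole Amide for a Fluorophenyl Amide

The compounds below may be only part of what the source reports. "The series", "measured", "known", "first", "only" and "open" are said of these compounds alone.

Three compounds share one core and were tested in a functional assay on Chem-3 cells for antagonist activity at metabotropic glutamate receptor 1 (Homo sapiens), read by fluorescence and calcium flux; a higher number here means a weaker inhibitor, a lower number a stronger inhibitor:

compound 1, `Cc1cc(C(=O)N2CCc3c(sc(NC(=O)c4ccc(Cl)cc4)c3C#N)C2)[nH]n1`: "not determined" (no result reported)
compound 2, `COc1ccc(C(=O)Nc2sc3c(c2C#N)CCN(C(=O)c2cc(C)n[nH]2)C3)cc1`: "not determined" (no result reported)
compound 3, `Cc1cc(C(=O)N2CCc3c(sc(NCc4ccccc4)c3C#N)C2)[nH]n1`: 1420 nM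

Compound 3 is the only one of the three with a number in this assay, so it stands alone: there is no second value to set it against, and nothing can be said about compound 1 or compound 2 beyond the fact that no result was reported for either.

The next compound, compound 4, `N#Cc1c(NCc2ccccc2)sc2c1CCN(C(=O)c1ccc(F)cc1)C2`, keeps the core of compound 3 and changes one part: 4-fluorophenyl in place of 3-methyl-1H-pyrazol-5-yl on a carbonyl carbon. In plain words, 4-fluorophenyl takes the place of 3-methyl-1H-pyrazol-5-yl on the carbonyl carbon that sits on the ring nitrogen of the core. Within the data shown here, no measured pair in this set shows what such a swap does, so the expectation rests on the single number for compound 3 alone.

With nothing to point the other way, compound 4 is expected to come out near compound 3, and the step from compound 3 to compound 4 is estimated as a 1.1-fold higher number from compound 3 to compound 4 (0.02 log units; within the scatter), a change that may well fall within the scatter. Compound 4 is therefore estimated at 1500 nM in this assay, with a range from 400 nM to 6000 nM.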

Compound 4, half-maximal inhibitory concentration: 600 nM
Estimate against measurement, compound 4: 2.5-fold (0.40 log units) above, and the stated range covers the measured number.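

In this assay, the group on the carbonyl carbon, whose other neighbour is an amide-type nitrogen in a ring, turns out to influence inhibition: 4-fluorophenyl in place of 3-methyl-1H-pyrazol-5-yl gives a 2.4-fold lower number from compound 3 to compound 4 (0.37 log units; beyond the scatter), a modest step but one beyond the usual scatter. The earlier compounds shown here offered a single number and no comparison, whereas this first pair shows that the position accepts a change of ring and that inhibition here does not depend on the hydrogen-bond donor and acceptor of the group that leaves, since 4-fluorophenyl has neither. No measurement available here explains why the number moves in this direction.

As far as these compounds go, whether the change in inhibition belongs to the fluorine or to the six-membered carbon ring stays open: a plain phenyl on the same carbonyl carbon would separate the two, and a cyclohexyl would test whether an aromatic ring is needed there at all. A single pair also cannot say whether the same swap would give a similar step when another part of the molecule changes.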